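Chain lengthening on the selenocyanate ether, compound 3 to 4

The source may report more compounds than this note shows. Statements on the series, on what has been measured and on what is new or still open speak of the compounds shown alone.

Values in a functional assay on MDA-MB-231 cells (Homo sapiens) for inhibition, read by MTT assay, with a stated time of 48 h; on this read-out higher numbers stand for weaker inhibition and lower numbers for stronger inhibition:
- compound 1 `COc1ccc(N(C)c2nc(C)nc3ccccc23)cc1C(=O)OCC[Se]C#N` gives 1480 nM
- compound 2 `COc1ccc(N(C)c2nc(C)nc3ccccc23)cc1C(=O)OCCC[Se]C#N` gives 1180 nM
- compound 3 `COc1ccc(N(C)c2nc(C)nc3ccccc23)cc1OCC[Se]C#N` gives 13 nM

Of the three, compound 3 stands lowest at 13 nM. Both steps that reach it are large: a 110-fold lower number from compound 1 to compound 3 (2.06 log units; beyond the scatter), and a 91-fold lower number from compound 2 to compound 3 (1.96 log units; beyond the scatter). These two steps replace the whole group on the aromatic carbon, so they say little about a change further along the chain.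

Compound 4 `COc1ccc(N(C)c2nc(C)nc3ccccc23)cc1OCCCC[Se]C#N` differs from compound 3 as follows: a group of 5 heavy atoms (3 carbon, 1 nitrogen, 1 selenium; no ring) in place of a group of 3 heavy atoms (1 carbon, 1 nitrogen, 1 selenium; no ring), on a saturated chain carbon, two bonds along the chain from an oxygen on an aromatic ring. For the measured compounds named here, the nearest precedent is another lengthening of a chain, in the pair carrying the carbonyl group: a 1.3-fold lower number from compound 1 to compound 2 (0.10 log units; within the scatter). It is a single comparison, made on a different linker, and no chain variant of compound 3 has been measured. No step beyond the scatter is therefore expected in this assay, though a modest rise cannot be excluded. The expected change is a 1.5-fold higher number from compound 3 to compound 4 (0.19 log units; within the scatter). Compound 4 is estimated at 20 nM, with an expected range from 6 nM to 70 nM.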

Compound 4, half-maximal inhibitory concentration: 1350 nM
Compound 4: the middle estimate sits 68-fold (1.83 log units) below what was measured, and the stated range ends below it.
By their numbers in this assay, from the lowest: compound 3; then compounds 2, 4 and 1 (each within the scatter of the next).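

In this assay the chain on the ether linker proves highly sensitive to length, with a 100-fold higher number from compound 3 to compound 4 (2.02 log units; beyond the scatter), a sensitivity the small step on the carbonyl-bearing linker gave no sign of. The ether linker alone therefore does not secure a low number: compound 4 sits level with the carbonyl-linked pair, with a 1.1-fold higher number from compound 2 to compound 4 (0.06 log units; within the scatter) and a 1.1-fold lower number from compound 1 to compound 4 (0.04 log units; within the scatter). No data are available to account for this steep dependence on chain length.

As far as these compounds go, whether the number climbs gradually or abruptly between these two chain lengths remains open, and a propylene chain on the same ether would settle that. Also open, from the compounds shown here alone, is whether a longer chain stays at this level, and whether a thiocyanate end behaves like the selenocyanate on the short ether chain.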